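The source may hold more compounds than are shown below. What is called first, only, known or untested is meant among the compounds shown, and "the series" means these compounds.

Measured so far in an assay for inhibition of apolipoprotein B-100 (Homo sapiens), tested at 100 nM; a lower number here means a stronger inhibitor, a higher number a weaker inhibitor:
- compound 1 `Cc1cccc(C(=O)Nc2ccc3c(c2)CC(NS(=O)(=O)c2ccccc2)C3)c1-c1ccc(F)cc1`: 1.2 nM
- compound 2 `Cc1ccc(-c2c(C)cccc2C(=O)Nc2ccc3c(c2)CC(NS(=O)(=O)c2ccccc2)C3)cc1`: 2.5 nM
- compound 3 `Cc1cccc(C(=O)Nc2ccc3c(c2)CC(NS(=O)(=O)c2ccccc2)C3)c1-c1ccc(Cl)cc1`: 2.4 nM

Compound 3 stands second highest of the three numbers in this assay. Its nearest neighbour is shown by a 1.0-fold lower number from compound 2 to compound 3 (0.02 log units; within the scatter), and its furthest by a 2.0-fold higher number from compound 1 to compound 3 (0.30 log units; within the scatter), so all three compounds sit close together.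

Compound 4 `COc1cccc(C(=O)Nc2ccc3c(c2)CC(NS(=O)(=O)c2ccccc2)C3)c1-c1ccc(Cl)cc1` differs from compound 3 in one place: methoxy in place of methyl on an aromatic carbon. The measured steps, a 2.1-fold higher number from compound 1 to compound 2 (0.32 log units; beyond the scatter), a 2.0-fold higher number from compound 1 to compound 3 (0.30 log units; within the scatter) and a 1.0-fold lower number from compound 2 to compound 3 (0.02 log units; within the scatter), all concern an exchange of fluoro, methyl or chloro on a different aromatic ring; none of them tests a methyl-to-methoxy exchange, and none of them moved the number beyond the scatter except the modest step from fluoro to methyl. Going by the values given here, no measured step therefore bears directly on this change, and the three exchanges that were measured stayed small. No step beyond the scatter is expected in this assay in either direction.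

For compound 4 in this assay the estimate is 3 nM, with a range from 1.2 nM to 8 nM, which is expected to mean a 1.3-fold higher number from compound 3 to compound 4 (0.10 log units; within the scatter).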

Compound 4, half-maximal inhibitory concentration: 2 nM
Compound 4: middle estimate off by 1.5-fold (0.18 log units), on the high side, and the stated range covers the measured number.
By their numbers in this assay, from the lowest: compounds 1, 4, 3 and 2 (each within the scatter of the next, the first and the last beyond it).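

In this assay, methoxy in place of methyl ortho to the 4-chlorophenyl group gives a 1.2-fold lower number from compound 3 to compound 4 (0.08 log units; within the scatter). Going by these compounds alone, the earlier steps all exchanged a group on a different aromatic ring, so this is the first look at this position, and it shows that one more heavy atom, an oxygen that adds a hydrogen-bond acceptor, can enter here while the number stays within the scatter. Nothing measured here explains why the number holds.

With only methyl and methoxy shown at this position, it remains open how an amine, a carboxylic acid or a longer chain such as ethoxy would read in this assay. Also open, as far as these compounds go, is whether the methoxy exchange would give a similar step with fluoro in place of chloro on the other ring.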